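The source may hold more compounds than are shown below. What is called first, only, known or untested is meant among the compounds shown, and "the series" means these compounds.

Measured compounds:
Compound 1 `CCC[C@@H](NC(=O)c1nccs1)c1cnc(Nc2ccc(C)nc2)c(Cl)c1` gives 8.2 nM in a functional assay on HEK293 cells for negative allosteric modulation of metabotropic glutamate receptor 5 (Homo sapiens), read by HTRF and inositol phosphate accumulation; a higher number here means a weaker inhibitor, a lower number a stronger inhibitor.
Compound 2 `Cc1ccc(Nc2ncc([C@H](NC(=O)c3nccs3)C(C)(C)C)cc2Cl)cn1` gives 30.9 nM in this assay.

Going by the values given here, compound 1 holds the lower of the two numbers, and the single measured step, a 3.8-fold higher number from compound 1 to compound 2 (0.58 log units; beyond the scatter), concerns the chain on the saturated carbon, not the amide ring. Compound 3 `CCC[C@@H](NC(=O)c1cscn1)c1cnc(Nc2ccc(C)nc2)c(Cl)c1` differs from compound 1 by 1,3-thiazol-4-yl in place of 1,3-thiazol-2-yl on a carbonyl carbon. Among the compounds with values here, no measured step touches this part of the molecule, so the expectation rests on the change alone, and a modest weakening is expected, a 2.4-fold higher number from compound 1 to compound 3 (0.39 log units; beyond the scatter), with wide uncertainty. Compound 3 is therefore estimated at 20 nM in this assay, with a range from 6 nM to 70 nM.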

Compound 3, half-maximal inhibitory concentration: 31.2 nM
For compound 3 the middle estimate is 1.6-fold (0.19 log units) below the measured one, and the stated range covers the measured number.
By their numbers in this assay, from the lowest: compound 1; then compounds 2 and 3 (each within the scatter of the next).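

Replacing 1,3-thiazol-2-yl with 1,3-thiazol-4-yl on the carbonyl carbon keeps the same atoms, joined differently, yet this assay records a 3.8-fold higher number from compound 1 to compound 3 (0.58 log units; beyond the scatter), so how this ring is attached matters. The amide ring, not only the chain on the saturated carbon, therefore affects the number. Nothing available explains this difference.

As far as these compounds go, whether a phenyl or 1,3-oxazol-2-yl on the carbonyl carbon would match compound 1 remains open. So does the result of combining tert-butyl with 1,3-thiazol-4-yl in one compound.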